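The source may hold more compounds than are shown below. What is called first, only, known or untested is meant among the compounds shown, and "the series" means these compounds.

Measured so far:
compound 1 `COc1cnc(-c2ccccn2)nc1N(C)C1CCCC1` — 775 mL/min/kg
compound 2 `COc1cnc(-c2ccccn2)nc1NCc1ccc(F)cc1F` — 79 mL/min/kg

In an in vitro ADME assay on microsomes from liver (Homo sapiens) for metabolic stability, read by LC-MS, tested at 0.05 uM (on this read-out lower numbers stand for slow clearance and higher numbers for fast clearance), compound 1 gives the higher of the two numbers; compound 2 gives 79 mL/min/kg, a gap beyond the scatter. Among the compounds with values here, no one-place step between these two is available.

Compound 3 `COc1cnc(-c2ccccn2)nc1N1CCCC1` is the next point: pyrrolidin-1-yl in place of cyclopentyl(methyl)amino on an aromatic carbon. Without a comparable step to lean on, the expectation for compound 3 is a moderate drop from compound 1, a 2.2-fold lower number from compound 1 to compound 3 (0.35 log units; beyond the scatter), possibly beyond the scatter but with wide uncertainty. Compound 3 is estimated at 350 mL/min/kg, with a range from 120 mL/min/kg to 900 mL/min/kg.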

Compound 3, clearance: 458 mL/min/kg
Estimate against measurement, compound 3: 1.3-fold (0.12 log units) below; measured number inside the range.
By their numbers in this assay, from the lowest: compound 2; then compounds 3 and 1 (each within the scatter of the next).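

In this assay, within the data shown here, the first one-place step, at this position on an aromatic carbon, is a 1.7-fold lower number from compound 1 to compound 3 (0.23 log units; within the scatter) and so does not separate pyrrolidin-1-yl from cyclopentyl(methyl)amino. On these two compounds, this change of group gives no measurable shift in clearance. No available evidence bears on the reason for this result.

Still open, on these data alone, is what a morpholin-4-yl or piperidin-1-yl group at this place would give in this assay. Also open, as far as these compounds go, is whether the step would look the same with a group other than methoxy on the neighbouring carbon of the shared core.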